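A few compounds are considered here, and "the series" means these few. Any claim that something is new, unique, unknown or untested is made for them only; others in the source may bear on it.

Among the measured compounds shown here, compound 1 `Cc1cc(C)c(NC(=O)N(Cc2c[nH]c(-c3ccccc3)n2)C2CCCCCC2)c(C)c1` is the first of two measured compounds; in an assay on microsomes from intestine for inhibition of acyl-CoA:cholesterol acyltransferase (Oryctolagus cuniculus) (a higher number here means a weaker inhibitor, a lower number a stronger inhibitor), compound 1 gives 750 nM. Compound 2 `Cc1cc(C)c(NC(=O)N(Cc2cccc(-c3csc(C)n3)c2)C2CCCCCC2)c(C)c1` differs from it in the side arm; in this assay compound 2 gives 180 nM. Of these two numbers compound 2 has the lower one, and its gap to compound 1 lies beyond the usual scatter, so compound 2 is the stronger inhibitor of the pair. Compound 3 `Cc1cc(C)c(NC(=O)N(Cc2cccc(-c3ccn(C)n3)c2)C2CCCCCC2)c(C)c1` differs from compound 2 in one place: 1-methyl-1H-pyrazol-3-yl in place of 2-methyl-1,3-thiazol-4-yl on an aromatic carbon. For the measured compounds named here, the group that leaves and the group that enters match in what is counted, and no measured pair here shows what such a swap does. The step expected is a 1.4-fold higher number from compound 2 to compound 3 (0.16 log units; within the scatter), not beyond the scatter, with a slight lean toward a higher number. Compound 3 is therefore estimated to give 260 nM in this assay, within a range from 100 nM to 700 nM.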

Compound 3, half-maximal inhibitory concentration: 42 nM
Estimate against measurement, compound 3: 6.2-fold (0.79 log units) above; the whole stated range lies above it.
By their numbers in this assay, from the lowest: compound 3; then compound 2; then compound 1.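

In this assay, putting 1-methyl-1H-pyrazol-3-yl in place of 2-methyl-1,3-thiazol-4-yl gives a 4.3-fold lower number from compound 2 to compound 3 (0.63 log units; beyond the scatter), so this aromatic carbon is sensitive to which five-membered aromatic ring it carries. The two groups match in heavy atoms, hydrogen-bond donors, hydrogen-bond acceptors and charge, so these counts alone do not separate them, yet the change in inhibition lies beyond the usual scatter. No measurement shown here explains this step.

It remains open what the methyl on the pyrazole contributes, since neither an unsubstituted 1H-pyrazol-3-yl nor an ethyl in place of that methyl appears among these compounds. As far as these compounds go, it is also open whether a six-membered ring such as pyridin-3-yl at this same carbon would match or surpass the 1-methyl-1H-pyrazol-3-yl group.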